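The compounds below may be only part of what the source reports. "The series", "measured", "known", "first", "only" and "open" are said of these compounds alone.

Compounds measured in an ADME assay on HepG2 cells (Homo sapiens) for cytotoxicity, read by CellTiter-Glo and resazurin assay, with a stated time of 72 h; a lower number here means that less compound is needed, a higher number that more compound is needed for the effect:
compound 1, `Cc1nnc(-c2cccc(-c3ccc(C(=O)N(Cc4cccc(OCCCCCC(=O)O)c4)C(C)C)cc3)c2)o1`: > 26000 nM
compound 2, `CC(C)N(Cc1cccc(OCCCCCC(=O)O)c1)C(=O)c1ccc(-c2ccc3c(c2)OCCO3)cc1`: > 21900 nM

Both values shown are limits of this assay, not numbers. For compound 1 the result is the limit > 26000 nM. For compound 2 the result is the limit > 21900 nM, so compound 2 stands only at a limit, with no readable position among the numbers. Going by the values given here, the one measured step, a step that the two limits leave unreadable from compound 1 to compound 2, is therefore of unreadable size; the two limits the limit of > 21900 nM in this assay, at which 1 of the 2 values shown sits, and the limit of > 26000 nM in this assay, at which 1 of the 2 values shown sits, are all that bears on the series.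

Compound 3, `CC(C)N(Cc1cccc(OCCCCCC(=O)O)c1)C(=O)c1ccc(-c2cccc(O)c2)cc1`, differs from compound 2 by 3-hydroxyphenyl in place of 2,3-dihydro-1,4-benzodioxin-6-yl on an aromatic carbon. Among the compounds with values here, no measured step bears directly on this change. Since the shared core carrying two different aryl groups gives only limits, compound 3 is expected to sit at or above the limit as well, with the step that the limit leaves unreadable from compound 2 to compound 3 estimated as none beyond the scatter. Compound 3 is estimated at 30000 nM, within 10000 nM to 100000 nM.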

Compound 3, half-maximal effective concentration: > 26000 nM
Compound 3 gave a limit, no number (the forecaster's own chance of this, stated with the estimate: 80%); the middle value does not contradict the limit.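

Compound 3 gives > 26000 nM, which is a limit and not a number, so its steps to compound 1 and compound 2 cannot be read. The compounds shown leave open where any of the three would stand as a number in this assay.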